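Expected Vero cell cytotoxicity after a methylphenyl swap

The source may hold more compounds than are shown below. What is called first, only, known or untested is meant among the compounds shown, and "the series" means these compounds.

Compound 1 `COC(=O)c1cc(-c2cccc(NC(=O)c3ccc(OCc4ccc(Cl)cc4)cc3)c2)on1`: > 80 ug/mL in an ADME assay on Vero cells (Chlorocebus sabaeus) for cytotoxicity, read by MTT assay, with a stated time of 72 h; on this read-out higher numbers stand for lower toxicity in this test and lower numbers for higher toxicity in this test
Compound 2 `COC(=O)c1cc(-c2cccc(NC(=O)c3ccc(/C=C/C(=O)c4cccc(Br)c4)cc3)c2)on1`: > 100 ug/mL in this assay
Compound 3 `COC(=O)c1cc(-c2cccc(NC(=O)c3ccc(/C=C/C(=O)c4ccc(F)cc4F)cc3)c2)on1`: > 40 ug/mL in this assay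

All three values are limits of this assay rather than numbers. Compound 1 reaches the limit described by the limit of > 80 ug/mL in this assay, at which 1 of the 3 values shown sits. Compound 2 reaches the limit described by the limit of > 100 ug/mL in this assay, at which 1 of the 3 values shown sits. Compound 3 reaches the limit described by the limit of > 40 ug/mL in this assay, at which 1 of the 3 values shown sits. Every value is a limit. The step that the two limits leave unreadable from compound 1 to compound 2, the step that the two limits leave unreadable from compound 1 to compound 3 and the step that the two limits leave unreadable from compound 2 to compound 3 therefore cannot be sized; none of the three compounds showed measurable toxicity up to its own limit.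

Compound 4 `COC(=O)c1cc(-c2cccc(NC(=O)c3ccc(/C=C/C(=O)c4ccccc4C)cc3)c2)on1` differs from compound 3 by the change (2-methylphenyl in place of 2,4-difluorophenyl on a carbonyl carbon). Going by the values given here, only the step from compound 2 to compound 3 bears on this site, and it is unreadable, so the data give no guide to the size or direction of the change at this site. The expectation is that compound 4, like compound 3, shows no toxicity within the tested range. The estimated step is a step that the limit leaves unreadable from compound 3 to compound 4. Compound 4 is therefore estimated at 100 ug/mL, with a range from 40 ug/mL to 200 ug/mL, and most likely the assay will again report only a limit.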

Compound 4, half-maximal cytotoxic concentration: > 25 ug/mL
Compound 4: a limit, no number; the forecaster's own chance of this, stated with the estimate: 85%; the middle value lies beyond the limit too.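

In this assay compound 4 gives > 25 ug/mL, which is a limit and not a number. Going by these compounds alone, compound 1, compound 2 and compound 3 also carry only limits, so no step to compound 4 can be read. As far as these compounds go, it remains open how toxic any of these four compounds is, and whether changing the group on the carbonyl carbon alters that toxicity.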